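From a 3-carboxypropyl Chain to a Bare Formyl

The compounds below may be only part of what the source reports. "The series", "measured", "known", "first", "only" and "open" are said of these compounds alone.

In a functional assay on NCI-H441 cells (Homo sapiens) for antiproliferative activity, with a stated time of 24 h (on this read-out lower numbers stand for stronger inhibition and higher numbers for weaker inhibition), compound 1 (`O=C(O)/C=C/C(=O)N1C/C(=C\c2ccccc2F)C(=O)/C(=C/c2ccccc2F)C1`) gives 29000 nM and compound 2 (`O=C(O)CCCC(=O)N1C/C(=C\c2ccccc2F)C(=O)/C(=C/c2ccccc2F)C1`) gives 60000 nM. Compound 2 therefore stands at the higher of the two numbers, as the weaker inhibitor of the pair. Compound 3 (`O=CN1C/C(=C\c2ccccc2F)C(=O)/C(=C/c2ccccc2F)C1`) keeps the shared core but carries hydrogen in place of 3-carboxypropyl on a carbonyl carbon. Going by the values given here, only one measured step bears on this change: a 2.1-fold higher number from compound 1 to compound 2 (0.32 log units; beyond the scatter). That step is modest, and it exchanges one carboxy-bearing chain for another, so it guides the present change only loosely. Among the compounds with values here, no measured compound lacks such a chain, and the data cannot fix the size of the move. Still, the number rose in a 2.1-fold higher number from compound 1 to compound 2 (0.32 log units; beyond the scatter) as 3-carboxypropyl entered, so a fall is expected when that group leaves. With the whole chain gone, the expected step is larger than the measured one, and it is a 5.0-fold lower number from compound 2 to compound 3 (0.70 log units; beyond the scatter). For compound 3 the estimated value is 12000 nM, with an expected range of 2500 nM to 50000 nM.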

Compound 3, half-maximal inhibitory concentration: 49000 nM
Beside the measured number, compound 3's estimate is 4.1-fold (0.61 log units) below it, and the stated range covers the measured number.
By their numbers in this assay, from the lowest: compounds 1, 3 and 2 (each within the scatter of the next, the first and the last beyond it).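

In this assay, taking the entire 3-carboxypropyl chain off the carbonyl carbon leaves the number within the scatter (a 1.2-fold lower number from compound 2 to compound 3 (0.09 log units; within the scatter)), and replacing 2-carboxyethenyl with hydrogen does the same (a 1.7-fold higher number from compound 1 to compound 3 (0.23 log units; within the scatter)). At this position, then, compound 3, with only a hydrogen on the carbonyl carbon, cannot be told apart from either chain-bearing compound, so neither chain is shown to matter relative to hydrogen, and the only step beyond the scatter remains the one between the two chains (a 2.1-fold higher number from compound 1 to compound 2 (0.32 log units; beyond the scatter)). No accompanying evidence bears on this result or on what lies behind it.

The three compounds leave open whether a group of another kind on this carbonyl carbon, such as a methyl, an aminoalkyl chain or a longer chain ending in a carboxylic acid, would move the number beyond the scatter from that of compound 3. They also leave open whether the small gap between the two chains reflects the length of the chain or its double bond, since compound 1 and compound 2 differ in both at once.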